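A 4-fluorophenyl group added to compound 2

The source may hold more compounds than are shown below. What is called first, only, known or untested is meant among the compounds shown, and "the series" means these compounds.

Of the compounds shown here, three have been measured in a functional assay on DU-145 cells (Homo sapiens) for cytotoxicity, read by trypan blue exclusion, with a stated time of 96 h; a lower number here means a stronger inhibitor, a higher number a weaker inhibitor. Compound 1 `COc1ccc(CS(=O)(=O)/C=C/c2c(OC)cccc2OC)c(N)c1` gives 750 nM, compound 2 `COC(=O)CNc1cc(CS(=O)(=O)/C=C/c2c(OC)cc(OC)cc2OC)ccc1OC` gives 100 nM, and compound 3 `COC(=O)CNc1cc(CS(=O)(=O)/C=C/c2cc(OC)c(OC)c(OC)c2)ccc1OC` gives 75000 nM. Compound 2 has the lowest number of the three, and the other two lie above it by more than the usual scatter. Compound 2 and compound 3 both carry the (methoxycarbonyl)methyl group, so that group does not settle the number by itself: compound 3 stands at 75000 nM.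

Compound 4 `COC(=O)C(Nc1cc(CS(=O)(=O)/C=C/c2c(OC)cc(OC)cc2OC)ccc1OC)c1ccc(F)cc1` has yet to be measured. It departs from compound 2 by a single change, (4-fluorophenyl in place of hydrogen on a saturated chain carbon bound to a carbonyl carbon and a nitrogen on an aromatic ring), which places 4-fluorophenyl in place of hydrogen on a saturated chain carbon bound to a carbonyl carbon and a nitrogen on an aromatic ring. For the measured compounds named here, no two measured compounds differ in one place only, so the data give no direct reading of a change at this carbon. A moderate step in this assay toward a weaker inhibitor is expected, probably just beyond the scatter, and the range is kept wide. The estimated change is a 3.0-fold higher number from compound 2 to compound 4 (0.48 log units; beyond the scatter). The value expected for compound 4 is 300 nM, within an estimated range of 50 nM to 2500 nM.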

Compound 4, half-maximal inhibitory concentration: 300 nM
The estimate for compound 4 equals the measured number at the digits printed; measured number inside the range.
By their numbers in this assay, from the lowest: compound 2; then compound 4; then compound 1; then compound 3.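

In this assay, placing 4-fluorophenyl in place of hydrogen on a saturated chain carbon bound to a carbonyl carbon and a nitrogen on an aromatic ring gives a 3.0-fold higher number from compound 2 to compound 4 (0.48 log units; beyond the scatter). For the compounds shown here, this is the first reading of a change at a single place, since the earlier compounds differed from one another in more than one place, and it shows that this carbon is not indifferent to substitution: the larger (4-fluorophenyl)(methoxycarbonyl)methyl group gives a weaker inhibitor than (methoxycarbonyl)methyl, yet the loss is only modest for a whole aromatic ring added at this carbon. Nothing available explains why the number moves in this direction.

On these data alone, with one substituent read at this carbon, it remains open whether the step follows from the aromatic ring, from its fluorine or from any group placed here, a question that a methyl group, an unsubstituted phenyl or a 4-methoxyphenyl at the same carbon would help to settle. As far as these compounds go, it is also open whether the step would keep its size if the methyl ester gave way to a carboxylic acid or a primary amide.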